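Swapping a Methoxy for a Chloro on the Aryl Ring

A few compounds are considered here, and "the series" means these few. Any claim that something is new, unique, unknown or untested is made for them only; others in the source may bear on it.

Of the compounds shown here, two have been measured so far. Compound 1 `O=C1N=C(N2N=C(c3ccccc3)CC2c2ccccc2O)S/C1=C1/C(=O)Nc2ccccc21` gives 4400 nM in a functional assay on cells (Melanoma cell, Homo sapiens) for cytotoxicity, read by sulforhodamine B assay, with a stated time of 48 h; a higher number here means a weaker inhibitor of growth, a lower number a stronger inhibitor of growth. Compound 2 `COc1ccc(C2CC(c3ccccc3)=NN2C2=NC(=O)/C(=C3\C(=O)Nc4ccccc43)S2)cc1` gives 4510 nM in this assay, which is the higher of the two numbers, though the step of a 1.0-fold higher number from compound 1 to compound 2 (0.01 log units; within the scatter) lies within the scatter, so the two compounds cannot be told apart on these data. Within the data shown here, that one step, 4-methoxyphenyl in place of 2-hydroxyphenyl on a saturated ring carbon, is the only measured comparison available. Compound 3 `O=C1N=C(N2N=C(c3ccccc3)CC2c2ccc(Cl)cc2)S/C1=C1/C(=O)Nc2ccccc21` differs from compound 2 by chloro in place of methoxy on an aromatic carbon. Among the measured compounds shown here, no measured step tests this exact exchange, but the single step seen at the same aryl ring produced no movement beyond the scatter, so the expected step of a 1.0-fold lower number from compound 2 to compound 3 (0.00 log units; within the scatter) in this assay is also small, with no confident direction. Compound 3 is therefore estimated at 4500 nM, within a range of 1800 nM to 11000 nM.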

Compound 3, concentration for total growth inhibition: 540 nM
Compound 3: the middle estimate sits 8.3-fold (0.92 log units) above what was measured; measured number outside the range, below it.
By their numbers in this assay, from the lowest: compound 3; then compounds 1 and 2 (each within the scatter of the next).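

The aryl ring on the saturated ring carbon is not indifferent in this assay: chloro in place of methoxy, para to a large group, gives an 8.4-fold lower number from compound 2 to compound 3 (0.92 log units; beyond the scatter), and 4-chlorophenyl in place of 2-hydroxyphenyl gives an 8.1-fold lower number from compound 1 to compound 3 (0.91 log units; beyond the scatter). Compound 1 and compound 2 lie within the scatter of each other, so that pair alone gave no sign that this ring could change the result, whereas compound 3 stands apart from both. Nothing available accounts for this difference between chloro and the other two groups.

On these data alone, it remains open whether chloro is unusual here or whether fluoro, bromo or methyl in the same place would give a similar number. It is also unknown whether an amine there would fall with compound 3 or with compound 1 and compound 2.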